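Compound 2 to compound 3: fluoro for hydrogen

A few compounds are considered here, and "the series" means these few. Any claim that something is new, unique, unknown or untested is made for them only; others in the source may bear on it.

In a functional assay on the whole organism with Mus musculus as the target (a lower number here means that less compound is needed, a higher number that more compound is needed for the effect), compound 2 `NC(=O)/C=C1\CCc2ccccc21` gives 31 mg/kg and compound 1 `NC(=O)/C=C1\CCc2ccc(Cl)cc21` gives 40 mg/kg. Among the compounds with values here, these are the only two numbers so far, and they lie within the scatter of each other, so neither ranks ahead of the other.

The next compound is compound 3 `NC(=O)/C=C1\CCc2ccc(F)cc21`, which carries fluoro in place of hydrogen on an aromatic carbon of compound 2: fluoro in place of hydrogen on an aromatic carbon. Within the data shown here, only one measured step bears on this change, the exchange of chloro for hydrogen on an aromatic carbon: a 1.3-fold lower number from compound 1 to compound 2 (0.11 log units; within the scatter). Among the measured compounds shown here, no measured step involves fluoro itself, so that halogen exchange is the sole guide.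

With that step inside the scatter, the expected 1.1-fold higher number from compound 2 to compound 3 (0.03 log units; within the scatter) is no shift beyond the scatter in this assay. For compound 3 the estimated value is 33 mg/kg, with an expected range of 16 mg/kg to 65 mg/kg.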

Compound 3, dose for half-maximal effect: 22 mg/kg
Beside the measured number, compound 3's estimate is 1.5-fold (0.18 log units) above it, within the range that was stated.
By their numbers in this assay, from the lowest: compounds 3, 2 and 1 (each within the scatter of the next).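

Fluoro gives the first direct reading for this group at this aromatic carbon in this assay: the step shows a 1.4-fold lower number from compound 2 to compound 3 (0.15 log units; within the scatter) and remains within the scatter. The exchange of one halogen for the other shows a 1.8-fold lower number from compound 1 to compound 3 (0.26 log units; within the scatter) and also remains within the scatter, so hydrogen, fluoro and chloro at this position give no step beyond the scatter among compounds 1, 2 and 3. No measured property accompanies these numbers, and nothing here accounts for how closely they lie.

From the compounds shown here alone, whether any group on this carbon can move the number beyond the scatter stays open, and a methoxy group, an amine or a carboxylic acid there would give a further reading. The amide and the other aromatic carbons of the shared core also stay open, as every step shown concerns this one position.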